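The source may report more compounds than this note shows. Statements on the series, on what has been measured and on what is new or still open speak of the compounds shown alone.

Measured so far:
- compound 1 `Nc1nc(F)nc2c1ncn2[C@@H]1O[C@H](CO)C=C1F`: > 100000 nM (a limit)
- compound 2 `Nc1nc(O)c2ncn([C@@H]3O[C@H](CO)C=C3F)c2n1`: > 100000 nM; > 100000 nM (2 entries) (a limit, both entries)

In an ADME assay on Vero cells (Chlorocebus sabaeus) for cytotoxicity (on this read-out higher numbers stand for weaker inhibition and lower numbers for stronger inhibition), compound 1 reads > 100000 nM as a limit of the assay, not a number. Compound 2 reads > 100000 nM; > 100000 nM (2 entries) as a limit too. Compound 3 `Nc1nc(N)c2ncn([C@@H]3O[C@H](CO)C=C3F)c2n1` has amino in place of fluoro on an aromatic carbon, between two ring nitrogen atoms, and the change counts as amino in place of fluoro on an aromatic carbon in full. Among the compounds with values here, no measured pair gives a step in this assay to go by. The expected move a number no higher from compound 1 to compound 3 (the limit leaves the size open) is estimated as none beyond the scatter, with no stronger inhibition expected. Compound 3 is estimated at 100000 nM with 40000 nM to 200000 nM as the expected range.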

Compound 3, half-maximal inhibitory concentration: > 100000 nM
Compound 3: a limit, no number; the forecaster's own chance of this, stated with the estimate: 85%; the middle value lies on the limit itself.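

In this assay, within the data shown here, compound 1 and compound 3 each give only a limit, so no step between them can be read: the limit of > 100000 nM in this assay, at which 2 of the 3 values shown sit. The compounds shown leave open whether amino in place of fluoro on an aromatic carbon changes this read-out at all.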